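The source may report more compounds than this note shows. Statements on the series, on what has been measured and on what is new or still open speak of the compounds shown alone.

Of the compounds shown here, two have been tested so far in an ADME assay on HEK293 cells (Homo sapiens) for cytotoxicity, read by reporter gene assay and resazurin assay, with a stated time of 48 h; a lower number here means that less compound is tolerated, a higher number that more compound is tolerated. Compound 1 `COc1c(Br)cccc1C(=O)Nc1ccccc1` reads > 100000 nM, which is a limit of the assay and not a number. Compound 2 `COc1ccc(Br)cc1C(=O)Nc1ccc(Sc2nc3ccccc3s2)cc1` reads > 100000 nM, and this too is a limit of the assay. Within the data shown here, compound 2 therefore stands with the only other compound tested, as the limit of > 100000 nM in this assay, at which 2 of the 2 values shown sit, shows.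

Compound 3 `COc1ccccc1C(=O)Nc1ccc(Sc2nc3ccccc3s2)cc1` is compound 2 with a single change, from 5-bromo-2-methoxyphenyl to 2-methoxyphenyl: hydrogen in place of bromo on an aromatic carbon. Hydrogen takes the place of bromo on an aromatic carbon, para to a methoxy group and meta to a large group. Among the measured compounds shown here, no measured pair shows what this swap does in this assay, so the expectation rests on the two limits alone. Since compound 2 reads > 100000 nM, no step beyond the scatter is expected. The most likely outcome is that the assay again reports only a limit for compound 3. The estimated change is a number no higher from compound 2 to compound 3 (the limit leaves the size open). The expected value for compound 3 is 100000 nM, with an estimated range from 50000 nM to 200000 nM.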

Compound 3, half-maximal cytotoxic concentration: > 100000 nM
Compound 3 ended at the assay's limit; the forecaster's own chance of this, stated with the estimate: 80%; the middle value lies on the limit itself.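

Compound 2 and compound 3 both sit at a limit of this assay and not at a number, so no step can be read for hydrogen in place of bromo on an aromatic carbon. The compounds shown leave open where the half-maximal cytotoxic concentration of each lies and whether this swap changes it.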